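Bromine position in a thiourea pair: cytotoxicity notes

The compounds below may be only part of what the source reports. "The series", "measured", "known", "first", "only" and "open" are said of these compounds alone.

Measured compounds:
compound 1, `FC(F)(F)c1cccc(NC(=S)Nc2ccccc2)c1`: 39000 nM
compound 2, `FC(F)(F)c1cccc(NC(=S)Nc2cccc(Br)c2)c1`: 9200 nM

In an ADME assay on MT4 cells (Homo sapiens) for cytotoxicity (on this read-out lower numbers stand for higher toxicity in this test and higher numbers for lower toxicity in this test), compound 2 gives 9200 nM, the lowest of the two numbers. Compound 1 gives 39000 nM. Among the compounds with values here, the only step measured is a 4.2-fold lower number from compound 1 to compound 2 (0.63 log units; beyond the scatter), so adding a bromine to the shared core of compound 1 made this assay read lower by a modest amount.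

Compound 3, `FC(F)(F)c1cccc(NC(=S)Nc2ccccc2Br)c1`, is the next compound. Its change from compound 2 is 2-bromophenyl in place of 3-bromophenyl on an amide-type nitrogen. Within the data shown here, no measured step compares a 2-bromophenyl with a 3-bromophenyl on an amide-type nitrogen; the one known step concerns only bromine added in place of hydrogen, and both compound 2 and compound 3 carry that bromine. The data give no basis for a shift in either direction, so the expected step of a 1.2-fold higher number from compound 2 to compound 3 (0.08 log units; within the scatter) is none beyond the scatter. Compound 3 is therefore estimated at 11000 nM, within a range of 4000 nM to 35000 nM.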

Compound 3, half-maximal cytotoxic concentration: 36000 nM
The estimate for compound 3 lay 3.3-fold (0.51 log units) below the measured number, and the stated range ends below it.
By their numbers in this assay, from the lowest: compound 2; then compounds 3 and 1 (each within the scatter of the next).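

In this assay, the place of the bromine decides the read-out: 2-bromophenyl in place of 3-bromophenyl on the amide-type nitrogen gives a 3.9-fold higher number from compound 2 to compound 3 (0.59 log units; beyond the scatter) and this step lies beyond the scatter. The lower number of compound 2 therefore does not follow from the presence of a bromine alone. With the 2-bromophenyl group, the bromo-for-hydrogen step gives a 1.1-fold lower number from compound 1 to compound 3 (0.03 log units; within the scatter) and stays within the scatter, whereas the same kind of step to the 3-bromophenyl group in compound 2 does not; nothing available accounts for this difference between the two bromine places.

Going by these compounds, whether 2-chlorophenyl and 3-chlorophenyl groups on the amide-type nitrogen would follow the bromine pair stays open. So does whether the difference between the two places survives a carbonyl in place of the thiocarbonyl.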